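A 3-methoxybenzyl swap on compound 1

The compounds below may be only part of what the source reports. "The series", "measured", "known", "first", "only" and "open" are said of these compounds alone.

Going by the values given here, in a functional assay on A-431 cells (Homo sapiens) (a lower number here means that less compound is needed, a higher number that more compound is needed for the effect), compound 1 (`COc1cccc(Nc2n[nH]c(-c3cccnc3Nc3cc(OC)cc(OC)c3)n2)c1`) gives 90 nM as its half-maximal effective concentration, and this is the only number available for the series. For compound 2 (`COc1cc(Nc2ncccc2-c2n[nH]c(Nc3cc(Cl)cc(Cl)c3)n2)cc(OC)c1`) the record reads "not determined" (no result reported) in this test. For compound 3 (`COc1cc(Nc2ncccc2-c2n[nH]c(Nc3ccc(C#N)cc3)n2)cc(OC)c1`) it reads "not determined" (no result reported) as well. Compound 1 therefore cannot be ranked against either of its relatives.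

Compound 4 (`COc1cccc(CNc2n[nH]c(-c3cccnc3Nc3cc(OC)cc(OC)c3)n2)c1`) keeps the core of compound 1 and differs in one place, with 3-methoxybenzyl in place of 3-methoxyphenyl on a nitrogen on an aromatic ring. Among the compounds with values here, no measured pair shows what such a change does here, so any expectation rests on the change itself and on compound 1 at 90 nM as the single anchor. A move towards a higher number, modestly beyond the usual scatter, seems more likely than a gain, although a result indistinguishable from compound 1 remains possible. The expected shift, a 3.3-fold higher number from compound 1 to compound 4 (0.52 log units; beyond the scatter) in this assay, is an estimate with wide margins. The estimate for compound 4 is 300 nM (expected range 80 nM to 1200 nM).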

Compound 4, half-maximal effective concentration: 120 nM
The estimate for compound 4 lay 2.5-fold (0.40 log units) above the measured number; the range from low to high includes it.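

In this assay, the series now has its first readable step, a 1.3-fold higher number from compound 1 to compound 4 (0.12 log units; within the scatter), and the two compounds cannot be told apart. On this nitrogen on an aromatic ring, 3-methoxybenzyl can therefore take the place of 3-methoxyphenyl with the core of compound 1 unchanged and without a difference that this test can resolve, something that compound 1 alone, as a single anchor, could not show. No data are available that would explain this result, whether from the structures or from any other measurement.

This single step leaves open how far the position accepts other groups, for example a longer chain such as 2-(3-methoxyphenyl)ethyl, or a benzyl group carrying an amine or a carboxylic acid in place of the methoxy group. It also leaves open whether the methoxy group matters to the result at all, a question that an unsubstituted benzyl group on the same nitrogen would address, and whether the same swap would behave alike in any other test.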